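Methyl in place of hydrogen on the series core

The compounds below may be only part of what the source reports. "The series", "measured", "known", "first", "only" and "open" are said of these compounds alone.

Values in a functional assay on HCT-116 cells (Homo sapiens) for cytotoxicity, read by MTT assay, with a stated time of 48 h, in the presence of a further agent that is not named here; on this read-out lower numbers stand for an effect already at smaller amounts and higher numbers for an effect only at larger amounts of compound:
Compound 1 `COc1ccc(-c2cc(NNC(=O)Nc3cc(Cl)nc(Cl)c3)nc3c2c(C)nn3C)cc1`: 82300 nM
Compound 2 `Cn1nc(C(F)(F)F)c2c(-c3ccccc3)cc(NNC(=O)Nc3cc(Cl)nc(Cl)c3)nc21`: 18100 nM
Compound 3 `Cn1ncc2c(-c3ccccc3)cc(NNC(=O)Nc3cc(Cl)nc(Cl)c3)nc21`: 6240 nM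

Compound 3 has the lowest of these three numbers. Compound 4 `Cc1nn(C)c2nc(NNC(=O)Nc3cc(Cl)nc(Cl)c3)cc(-c3ccccc3)c12` carries methyl in place of hydrogen on an aromatic carbon. Going by the values given here, the one measured step at this carbon is modest: a 2.9-fold lower number from compound 2 to compound 3 (0.46 log units; beyond the scatter), with hydrogen in place of trifluoromethyl. Among the compounds with values here, no measured step covers methyl itself, so this is only a loose guide. A modest rise in this assay is expected, of about the same size or smaller, and the range also allows for no change beyond the scatter. The expected change is a 1.7-fold higher number from compound 3 to compound 4 (0.23 log units; within the scatter). The estimated value for compound 4 is 10500 nM, with an expected range of 4500 nM to 28000 nM.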

Compound 4, half-maximal effective concentration: 80000 nM
Compound 4: the middle estimate sits 7.6-fold (0.88 log units) below what was measured, and the stated range ends below it.
By their numbers in this assay, from the lowest: compound 3; then compound 2; then compounds 4 and 1 (each within the scatter of the next).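

In (this assay), methyl on this aromatic carbon brings a large step against hydrogen (a 13-fold higher number from compound 3 to compound 4 (1.11 log units; beyond the scatter)). Methyl also compares unfavourably with trifluoromethyl at this carbon (a 4.4-fold higher number from compound 2 to compound 4 (0.65 log units; beyond the scatter)), so hydrogen gives the lowest number of the three groups here. With methyl at this carbon, hydrogen in place of methoxy on an aromatic carbon stays within the scatter (a 1.0-fold lower number from compound 1 to compound 4 (0.01 log units; within the scatter)).

From the compounds shown here alone, whether methoxy has any effect with hydrogen at the first carbon, and where an ethyl group or an amine would fall there, remains open. No available evidence accounts for the methyl step.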